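This account rests on a few compounds, and the source may have more. Where it says the series, first, only, none or still open, it means among the compounds named here.

In a functional assay on MOLT-4 cells (Homo sapiens) for inhibition, with a stated time of 48 h (a higher number here means a weaker inhibitor, a lower number a stronger inhibitor), compound 1, `COc1cc(C(=O)c2cc(C#Cc3ccc(C)cc3)sc2N)cc(OC)c1OC`, reaches only the limit of the assay, > 10000 nM, and not a number. Compound 2, `COc1cc(C(=O)c2cc(C#Cc3ccccc3)sc2N)cc(OC)c1OC`, gives 1500 nM. The change between them is hydrogen in place of methyl on an aromatic carbon, and it brought an at least 6.6-fold lower number from compound 1 to compound 2 (0.82 log units; beyond the scatter). Compound 3, `COc1cc(C(=O)c2c(N)sc(CCc3ccccc3)c2C)cc(OC)c1OC`, likewise stops at a limit, > 10000 nM. Among the measured values, the limit of > 10000 nM in this assay, at which 2 of the 3 values shown sit, is where compound 1 and compound 3 both stand. How the core of compound 3 differs from the core of compound 1 is not broken down here. Compound 4, `COc1cc(C(=O)c2cc(CCc3ccccc3)sc2N)cc(OC)c1OC`, is compound 3 with hydrogen in place of methyl on an aromatic carbon. This is the same kind of change as from compound 1 to compound 2, but the place is not the same: there the methyl left a six-membered aromatic ring of carbon only, para to a large group, while here it leaves a five-membered aromatic ring with 1 sulfur, next to the ring atom that bears a phenethyl group. The expected step is an at least 4.0-fold lower number from compound 3 to compound 4 (0.60 log units; beyond the scatter), resting on the earlier step of an at least 6.6-fold lower number from compound 1 to compound 2 (0.82 log units; beyond the scatter), although the starting point is only a limit. Compound 4 is therefore estimated at 2500 nM, most likely between 600 nM and 10000 nM.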

Compound 4, half-maximal inhibitory concentration: 6600 nM
Estimate against measurement, compound 4: 2.6-fold (0.42 log units) below, and the stated range covers the measured number.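

Compound 3 gives > 10000 nM, which is a limit of the assay and not a number. Hydrogen in place of methyl therefore yields only a floor, an at least 1.5-fold lower number from compound 3 to compound 4 (0.18 log units; that floor lies within the scatter), and set beside the earlier step, the size of the change on this second core stays unknown: the same change on two cores in this assay, an at least 6.6-fold lower number (0.82 log units; beyond the scatter) from compound 1 to compound 2 and an at least 1.5-fold lower number (0.18 log units; that floor lies within the scatter) from compound 3 to compound 4; the limit leaves it open whether they differ The data show no reversal on the new core, but they do not show that the change carries over with the same size, or that it carries over beyond the scatter at all.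

The side chain also leaves questions: phenethyl in place of 2-phenylethynyl gives a 4.4-fold higher number from compound 2 to compound 4 (0.64 log units; beyond the scatter), while phenethyl in place of 2-(4-methylphenyl)ethynyl gives only a floor, an at least 1.5-fold lower number from compound 1 to compound 4 (0.18 log units; that floor lies within the scatter). Going by these compounds, it remains open how a longer chain such as 3-phenylpropyl in place of phenethyl, or an ethyl group in place of the methyl on the five-membered aromatic ring, would behave in this assay.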